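Bromo for Methoxy: Expected Effect on Cytotoxicity

The compounds below may be only part of what the source reports. "The series", "measured", "known", "first", "only" and "open" are said of these compounds alone.

Compound 1 `COc1ccc(/C=C/C(=O)c2c(C)[n+]([O-])c3ccccc3[n+]2[O-])cc1` carries a methoxy group on an aromatic carbon. Among the compounds with values here, in an ADME assay on HPC cells (Homo sapiens) for cytotoxicity, with a stated time of 48 h (on this read-out lower numbers stand for higher toxicity in this test and higher numbers for lower toxicity in this test), compound 1 gives 92000 nM, the highest of the two numbers available, though the only other number lies within the scatter of it. That other number belongs to compound 2 `Cc1c(C(=O)/C=C/c2ccc(F)cc2)[n+]([O-])c2ccccc2[n+]1[O-]`, which in this assay gives 48000 nM. Within the data shown here, the step of a 1.9-fold lower number from compound 1 to compound 2 (0.28 log units; within the scatter) is the only measured comparison that bears on the new compound. Compound 3 `Cc1c(C(=O)/C=C/c2ccc(Br)cc2)[n+]([O-])c2ccccc2[n+]1[O-]` makes a related change: bromo in place of methoxy on an aromatic carbon. Since the fluoro swap stayed within the scatter, no step beyond the scatter is expected for the bromo swap either. For compound 3 the estimate in this assay is 60000 nM, with a range from 25000 nM to 150000 nM, an expected step of a 1.5-fold lower number from compound 1 to compound 3 (0.19 log units; within the scatter).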

Compound 3, half-maximal cytotoxic concentration: 43000 nM
Beside the measured number, compound 3's estimate is 1.4-fold (0.14 log units) above it; low and high end bracket the measured number.
By their numbers in this assay, from the lowest: compounds 3, 2 and 1 (each within the scatter of the next, the first and the last beyond it).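

In this assay, within the data shown here, going from 4-methoxyphenyl to 4-bromophenyl gives a 2.1-fold lower number from compound 1 to compound 3 (0.33 log units; beyond the scatter) and is the only step at this aromatic carbon that lies beyond the scatter, though it remains modest. The two halogen compounds cannot be told apart, with a 1.1-fold lower number from compound 2 to compound 3 (0.05 log units; within the scatter) as the step between them. Nothing available explains why these numbers fall where they do.

Other groups on this aromatic carbon, such as an amine, a carboxylic acid or a longer chain, remain open. It is therefore unknown how far the number can move through changes at this place.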